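From 4-methoxybenzyl to 4-chlorobenzyl on a shared core

This account rests on a few compounds, and the source may have more. Where it says the series, first, only, none or still open, it means among the compounds named here.

For the measured compounds named here, in a functional assay on NSCLC cells (Homo sapiens) for cytotoxicity, with a stated time of 48 h (on this read-out higher numbers stand for weaker inhibition of growth and lower numbers for stronger inhibition of growth), compound 1 (`COc1ccc(CN2C(=O)/C(=C\c3cc(OC)c(OC)c(OC)c3)c3ccccc32)cc1`) gives 9300 nM, the lowest of the three numbers known so far. Compound 2 (`COc1cc(/C=C2/C(=O)N(C)c3ccc(O)cc32)cc(OC)c1OC`) gives 24600 nM and compound 3 (`COc1ccc2c(c1)/C(=C\c1cc(OC)c(OC)c(OC)c1)C(=O)N2C`) gives 46800 nM, and both numbers lie above that of compound 1 by more than the scatter.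

The compound still to be measured is compound 4 (`COc1cc(/C=C2\C(=O)N(Cc3ccc(Cl)cc3)c3ccccc32)cc(OC)c1OC`). It keeps the core of compound 1 and carries 4-chlorobenzyl in place of 4-methoxybenzyl, which puts chloro in place of methoxy on an aromatic carbon, para to a large group (chloro in place of methoxy on an aromatic carbon).

Going by the values given here, only one measured step touches a methoxy group: a 1.9-fold higher number from compound 2 to compound 3 (0.28 log units; within the scatter), which stays within the scatter. That step places a methyl on an oxygen elsewhere in the molecule, so it is only a weak guide to the exchange at hand. Among the compounds with values here, no measured compound carries chloro, and no measured step alters the 4-methoxybenzyl group. On this evidence, no change beyond the scatter is expected in this assay. The estimated step is a 1.2-fold lower number from compound 1 to compound 4 (0.07 log units; within the scatter). Compound 4 is expected at 8000 nM, with an estimated range from 3500 nM to 19000 nM.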

Compound 4, concentration for total growth inhibition: 14400 nM
The estimate for compound 4 lay 1.8-fold (0.26 log units) below the measured number; measured number inside the range.
By their numbers in this assay, from the lowest: compounds 1, 4, 2 and 3 (each within the scatter of the next, the first and the last beyond it).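

In this assay, for the compounds shown here, the exchange of 4-methoxybenzyl for 4-chlorobenzyl gives a 1.5-fold higher number from compound 1 to compound 4 (0.19 log units; within the scatter), the first reading of a change on this group, as the earlier compounds offered no step that touched it. On an aromatic carbon, para to a large group, methoxy, with its two heavy atoms and one hydrogen-bond acceptor, gives way to chloro, with one heavy atom and no hydrogen-bond acceptor, without a change beyond the scatter, so on this pair the acceptor count and the size of the substituent go with no clear shift in the number. Nothing available speaks to why the two compounds read so alike.

Going by these compounds alone, it remains open whether this position would stay as undemanding with an amine, a carboxylic acid or a longer chain in place of chloro, since methoxy and chloro are the only two groups seen there. Also open, from the compounds shown here alone, is what the benzyl group itself contributes, since compound 2 and compound 3 differ from compound 1 in more than one place and so cannot isolate it.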